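Trading Two Fluorines for Two Hydroxyls on a Growth Inhibitor

This account rests on a few compounds, and the source may have more. Where it says the series, first, only, none or still open, it means among the compounds named here.

In a functional assay on SK-OV-3 cells (Homo sapiens) for cytotoxicity (a lower number here means a stronger inhibitor of growth, a higher number a weaker inhibitor of growth), compound 1 `COc1ccc(C2=C(c3ccc(SC)cc3)CC3CCCN3C2=O)cc1C` gives 15000 nM and compound 3 `COc1ccc(C2=C(c3ccc(SC)cc3)CC3CCCN3C2=O)cc1OC` gives 9000 nM as its result. Compound 2 `CSc1ccc(C2=C(c3ccc(F)c(F)c3)C(=O)N3CCCC3C2)cc1` stands apart at 100 nM as the lowest number of the three, which makes it the strongest inhibitor in this small set.

The next candidate, compound 4 `CSc1ccc(C2=C(c3ccc(O)c(O)c3)C(=O)N3CCCC3C2)cc1`, has not been measured yet. It is compound 2 with a single change on a double-bonded ring carbon, where 3,4-dihydroxyphenyl takes the place of 3,4-difluorophenyl 3,4-dihydroxyphenyl in place of 3,4-difluorophenyl on a double-bonded ring carbon and nothing else differs.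

Among the measured compounds shown here, two measured steps bear on this change. Swapping the group at this same place gave a 150-fold lower number from compound 1 to compound 2 (2.18 log units; beyond the scatter) as a large step, with 3,4-difluorophenyl replacing 4-methoxy-3-methylphenyl. Methoxy in place of methyl on that group gave a 1.7-fold lower number from compound 1 to compound 3 (0.22 log units; within the scatter) and stayed within the scatter. So compound 1 and compound 3, the two with oxygen on this group, both sit far above compound 2, and compound 4 brings oxygen back. For the measured compounds named here, no measured compound carries hydroxyl groups, which leaves the size uncertain.

In this assay the expected step is a 15-fold higher number from compound 2 to compound 4 (1.18 log units; beyond the scatter) toward weaker inhibition. For compound 4 the estimated value is 1500 nM with an expected range from 200 nM to 10000 nM in this test.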

Compound 4, concentration for 50% growth inhibition: 80000 nM
Beside the measured number, compound 4's estimate is 53-fold (1.73 log units) below it, and the stated range ends below it.
By their numbers in this assay, from the lowest: compound 2; then compounds 3 and 1 (each within the scatter of the next); then compound 4.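

The new step shows how sensitive this position is: in this assay, 3,4-dihydroxyphenyl in place of 3,4-difluorophenyl gives an 800-fold higher number from compound 2 to compound 4 (2.90 log units; beyond the scatter). Both groups have the same count of 8 heavy atoms and the same aromatic ring, so a large change in growth inhibition here does not need any change in heavy-atom count, only fluorine giving way to oxygen, with hydrogen-bond donors going from 0 to 2. The earlier compounds suggested that oxygen-bearing groups at this position sit far above compound 2, but they did not show that such groups differ among themselves beyond the scatter, and 3,4-dihydroxyphenyl in place of 4-methoxy-3-methylphenyl gives a 5.3-fold higher number from compound 1 to compound 4 (0.73 log units; beyond the scatter); nothing available here explains why these numbers move as they do.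

Still open, on these data alone, is whether both hydroxyl groups are needed for this loss, which a phenyl group mixing fluorine and hydroxyl could help to separate. Also open, as far as these compounds go, is how an amine or a carboxylic acid on this phenyl group would compare, and whether the same order holds when the 4-(methylsulfanyl)phenyl group is replaced.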